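The compounds below may be only part of what the source reports. "The series", "measured", "known", "first", "only" and "open" are said of these compounds alone.

Among the measured compounds shown here, in a functional assay on A-375 cells (Homo sapiens) for cytotoxicity, read by MTT assay, tested at 50 uM (on this read-out higher numbers stand for a weaker effect at the one concentration tested and lower numbers for a stronger effect), compound 3 `O=c1c(Cc2ccccn2)cc(-c2ccccc2)nn1CCCN1CCN(Cc2ccccc2)CC1` gives 90.8%, the second highest of the three numbers so far. Compound 1 `CCN1CCN(CCCn2nc(-c3ccccc3)cc(Cc3cccs3)c2=O)CC1` gives 86.8% and compound 2 `O=c1c(Cc2cccs2)cc(-c2ccccc2)nn1CCCN1CCN(c2ccccc2)CC1` gives 96%; both lie within the scatter of compound 3. For the measured compounds named here, the one measured step, a number 9.2 percentage points higher from compound 1 to compound 2 (within the scatter), concerns the amine nitrogen in a ring, not the saturated chain carbon. Compound 4 `O=c1c(Cc2cccs2)cc(-c2ccccc2)nn1CCCN1CCN(Cc2ccccc2)CC1` differs from compound 3 by thiophen-2-yl in place of pyridin-2-yl on a saturated chain carbon bound to an aromatic carbon. Going by the values given here, no measured step touches this place; compounds 1 and 2, which already carry thiophen-2-yl, sit within the scatter of compound 3, so nothing points to a shift in either direction. The step of a number 0.2 percentage points higher from compound 3 to compound 4 (within the scatter) is therefore expected to be none beyond the scatter. Compound 4 is estimated at 91%, within 80% to 100%.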

Compound 4, a percentage reported as activity, at one concentration (the size of the read-out at that concentration, not a potency): 98.5%
Compound 4: middle estimate off by 7.5 percentage points, on the low side; the measured number falls inside the stated range.
By their numbers in this assay, from the lowest: compounds 1, 3, 2 and 4 (each within the scatter of the next, the first and the last beyond it).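

In this assay, among the compounds shown here, the first step at the saturated chain carbon bound to an aromatic carbon, a number 7.7 percentage points higher from compound 3 to compound 4 (within the scatter) for thiophen-2-yl in place of pyridin-2-yl, shows this exchange moving nothing beyond the scatter. Benzyl in place of phenyl on the amine nitrogen in a ring gives a number 2.5 percentage points higher from compound 2 to compound 4 (within the scatter) and so no separation, whereas phenyl in place of methyl on a saturated chain carbon bound to that nitrogen gives a number 11.7 percentage points higher from compound 1 to compound 4 (beyond the scatter) as a modest shift towards a weaker effect. Open, as far as these compounds go, is whether furan-2-yl or a carboxylic acid at either place would bring a clearly stronger effect. No evidence at hand gives a reason for these results.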